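Chloro substitution in a glycine transporter inhibitor series

A few compounds are considered here, and "the series" means these few. Any claim that something is new, unique, unknown or untested is made for them only; others in the source may bear on it.

Measured compounds in an assay for inhibition of sodium- and chloride-dependent glycine transporter 1 (Homo sapiens); a lower number here means a stronger inhibitor, a higher number a weaker inhibitor:
compound 1 `COc1ccc(Sc2ccccc2N2CC(C)N(CC(=O)O)CC2C)cc1`, 580 nM
compound 2 `COc1ccc(Sc2ccccc2N2C[C@@H](C)N(CC(=O)O)C[C@@H]2C)cc1`, 160 nM
compound 3 `COc1ccc(Sc2ccccc2N2C[C@H](C)N(CC(=O)O)C[C@@H]2C)cc1`, 18000 nM

Compound 1 gives the second highest of the three numbers in this assay. Its nearest neighbour is compound 2, with a 3.6-fold lower number from compound 1 to compound 2 (0.56 log units; beyond the scatter); the furthest is compound 3, with a 31-fold higher number from compound 1 to compound 3 (1.49 log units; beyond the scatter). Between the two defined isomers the gap is a 110-fold higher number from compound 2 to compound 3 (2.05 log units; beyond the scatter). All three measured steps rest on configuration alone, as shown by the fact that one of compounds 1 and 2 is drawn with a defined configuration and the other without, at the place where they differ, the fact that one of compounds 1 and 3 is drawn with a defined configuration and the other without, at the place where they differ and (the fact that compounds 2 and 3 differ only in the configuration as drawn); the atoms and bonds are the same throughout.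

Compound 4 `COc1ccc(Sc2ccc(Cl)cc2N2CC(C)N(CC(=O)O)CC2C)cc1` keeps the undefined configuration of compound 1 and adds (chloro in place of hydrogen on an aromatic carbon). Among the measured compounds shown here, none of the measured steps touches a change of this kind, so no step gives a direction for it. The expectation for the move from compound 1 to compound 4 is therefore one of no change beyond the scatter, no change at the digits printed from compound 1 to compound 4 (within the scatter), with a wide range to reflect the absence of any guiding step. Compound 4 is estimated at 580 nM, within 180 nM to 1900 nM.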

Compound 4, half-maximal inhibitory concentration: 1700 nM
The estimate for compound 4 lay 2.9-fold (0.47 log units) below the measured number; low and high end bracket the measured number.
By their numbers in this assay, from the lowest: compound 2; then compound 1; then compound 4; then compound 3.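

In this assay, among the compounds shown here, chloro in place of hydrogen on an aromatic carbon, para to a (4-methoxyphenyl)sulfanyl group, gives a 2.9-fold higher number from compound 1 to compound 4 (0.47 log units; beyond the scatter), the first step that changes atoms rather than configuration. This position therefore responds to substitution, and the direction for chloro here is towards a weaker inhibitor, though the step is smaller than the configurational gap of a 110-fold higher number from compound 2 to compound 3 (2.05 log units; beyond the scatter). The measured configurational steps have no bearing on this change, so nothing shown gives a cause for it.

From the compounds shown here alone, compounds 1 and 4 are both drawn without configuration, so it remains open whether chloro has a step of the same size on the defined isomer of compound 2. Also open, going by these compounds, is whether fluoro, methyl or a nitrile at this position would move the number in the same direction.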